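Replacing 4-(trifluoromethyl)phenyl with naphthalen-2-yl on an oxygen

A few compounds are considered here, and "the series" means these few. Any claim that something is new, unique, unknown or untested is made for them only; others in the source may bear on it.

Of the compounds shown here, three with a shared core have been measured in a functional assay on MCF7 cells (Homo sapiens) for inhibition, read by MTT assay, with a stated time of 72 h; a lower number here means a stronger inhibitor, a higher number a weaker inhibitor. Compound 1 `O=C(O)CCCCCCC(=O)Nc1ccc(C2=C(c3ccc(O)cc3)C3CC(S(=O)(=O)Oc4cccc5ccccc45)C2O3)cc1` gives 4700 nM, compound 2 `Cc1ccccc1OS(=O)(=O)C1CC2OC1C(c1ccc(NC(=O)CCCCCCC(=O)O)cc1)=C2c1ccc(O)cc1` gives 7900 nM, and compound 3 `O=C(O)CCCCCCC(=O)Nc1ccc(C2=C(c3ccc(O)cc3)C3CC(S(=O)(=O)Oc4ccc(C(F)(F)F)cc4)C2O3)cc1` gives 24000 nM. Compound 3 therefore has the highest number of the three and is the weakest inhibitor of this small set.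

Compound 4 `O=C(O)CCCCCCC(=O)Nc1ccc(C2=C(c3ccc(O)cc3)C3CC(S(=O)(=O)Oc4ccc5ccccc5c4)C2O3)cc1` has naphthalen-2-yl in place of 4-(trifluoromethyl)phenyl on an oxygen attached to a sulfonyl sulfur: naphthalen-2-yl in place of 4-(trifluoromethyl)phenyl on an oxygen.

The nearest guide is compound 1, which carries naphthalen-1-yl on that oxygen. The measured change to 4-(trifluoromethyl)phenyl was a 5.1-fold higher number from compound 1 to compound 3 (0.71 log units; beyond the scatter). Starting from 2-methylphenyl, the same change was a 3.0-fold higher number from compound 2 to compound 3 (0.48 log units; beyond the scatter). The swap between the two other groups was a 1.7-fold higher number from compound 1 to compound 2 (0.23 log units; within the scatter), which lies within the scatter. Naphthalen-2-yl itself is untested, so this guide is imperfect.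

A modest fall in the number is expected, an estimated 3.7-fold lower number from compound 3 to compound 4 (0.57 log units; beyond the scatter). The estimate for compound 4 is 6500 nM, with an expected range of 2500 nM to 17000 nM.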

Compound 4, half-maximal inhibitory concentration: 18900 nM
For compound 4 the middle estimate is 2.9-fold (0.46 log units) below the measured one; the measured number lies above the stated range.
By their numbers in this assay, from the lowest: compounds 1 and 2 (each within the scatter of the next); then compounds 4 and 3 (each within the scatter of the next).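

In this assay the step from naphthalen-1-yl to naphthalen-2-yl on the oxygen attached to the sulfonyl sulfur gives a 4.0-fold higher number from compound 1 to compound 4 (0.60 log units; beyond the scatter) and shows that carrying two aromatic rings at this place does not alone keep the number low, since how the naphthalene is joined also matters. Naphthalen-2-yl also falls behind 2-methylphenyl with a 2.4-fold higher number from compound 2 to compound 4 (0.38 log units; beyond the scatter) while the comparison with 4-(trifluoromethyl)phenyl gives a 1.3-fold lower number from compound 3 to compound 4 (0.10 log units; within the scatter) and so does not separate those two groups. No measurement available here explains these differences.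

The compounds shown leave open whether an amine or a methoxy group on the aromatic ring at this place would bring the number below that of compound 1. They also leave open whether the same order of groups would hold with a shorter chain ending in the carboxylic acid.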